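Swapping a silyl ether for an acetate on a shared core

A few compounds are considered here, and "the series" means these few. Any claim that something is new, unique, unknown or untested is made for them only; others in the source may bear on it.

Compound 1 `C=C1CC[C@@H]2[C@](C)(CO[Si](C)(C)C(C)(C)C)[C@H](O)CC[C@@]2(C)[C@@H]1C/C=C1/C(=O)OC[C@H]1OC(C)=O`: 10.4 uM
Compound 2 `C=C1CC[C@@H]2[C@](C)(CO[Si](C)(C)C(C)(C)C)[C@H](O)CC[C@@]2(C)[C@@H]1C/C=C1/C(=O)OC[C@H]1O`: 47 uM
Compound 3 `C=C1CC[C@@H]2[C@](C)(COC(c3ccccc3)(c3ccccc3)c3ccccc3)[C@H](OC(C)=O)CC[C@@]2(C)[C@@H]1C/C=C1/C(=O)OC[C@H]1OC(C)=O`: 22.7 uM

Of the compounds shown here, three on the shared core have been tested in a functional assay on MCF7 cells (Homo sapiens) for cytotoxicity, read by sulforhodamine B assay; a higher number here means that more compound is needed for the effect, a lower number that less compound is needed. Compound 2 stands at the highest of the three numbers; the nearest to it is compound 3, and the furthest is compound 1, which needs the least compound of the three. Among the compounds with values here, the one single-point step among them runs a 4.5-fold higher number from compound 1 to compound 2 (0.66 log units; beyond the scatter), hydrogen in place of acetyl on an oxygen on a saturated carbon.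

Compound 4 `C=C1CC[C@@H]2[C@](C)(COC(C)=O)[C@H](O)CC[C@@]2(C)[C@@H]1C/C=C1/C(=O)OC[C@H]1O` is not yet measured in this assay. Relative to compound 2 it carries a group of 3 heavy atoms (2 carbon, 1 oxygen; no ring) in place of a group of 7 heavy atoms (6 carbon, 1 silicon; no ring), on an oxygen on a saturated carbon, an acetyl entering where a group of 7 heavy atoms (6 carbon, 1 silicon; no ring) leaves, on an oxygen on a saturated carbon whose other neighbours are a saturated chain carbon.

Within the data shown here, no measured step tests this exchange: the step from compound 1 to compound 2 changes a different oxygen, and compound 3 differs from both in several places at once. With nothing that bears directly on it, the step of a 1.2-fold lower number from compound 2 to compound 4 (0.07 log units; within the scatter) is expected to stay within the scatter. Compound 4 is therefore estimated at 40 uM in this assay, within a range from 14 uM to 115 uM.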

Compound 4, concentration for half-maximal effect: 18.3 uM
The estimate for compound 4 lay 2.2-fold (0.34 log units) above the measured number, within the range that was stated.
By their numbers in this assay, from the lowest: compounds 1, 4 and 3 (each within the scatter of the next, the first and the last beyond it); then compound 2.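

In this assay, the exchange at this oxygen on a saturated carbon gives a 2.6-fold lower number from compound 2 to compound 4 (0.41 log units; beyond the scatter), so this place, which the earlier single-point step did not touch, does affect the number. The group of 7 heavy atoms (6 carbon, 1 silicon) is therefore not needed to keep the number at the level of compound 2, and with an acetyl in its place, on a core whose other oxygen stays free, less compound is needed. Nothing available explains why the number moves in this direction.

The single step cannot separate the departure of the silicon-bearing group from the arrival of the acetyl, and the compounds shown do not tell how a bare hydroxyl, a methyl ether or a benzoyl ester on this oxygen would compare. Within the data shown here, they also leave open whether this exchange would give a step of similar size and direction if the other oxygen carried an acetyl, as it does in compound 1, since no single-point step tests that combination.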